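Phenyl Removal on a Glycoside Bearing a Cyclohexyloxyphenyl Ether

The compounds below may be only part of what the source reports. "The series", "measured", "known", "first", "only" and "open" are said of these compounds alone.

Measured compounds:
compound 1 `CO[C@H]1O[C@H](COc2ccccc2)[C@@H](O)[C@H](O)[C@H]1Oc1ccc(OC2CCCCC2)cc1`, -8%
compound 2 `CO[C@@H]1O[C@H](COc2ccc(-c3ccccc3)cc2)[C@@H](O)[C@H](O)[C@H]1Oc1ccc(OC2CCCCC2)cc1`, 30%

In a functional assay on MDA-MB-435 cells (Homo sapiens) for cytotoxicity, read by MTT assay, with a stated time of 48 h, tested at 20 uM (on this read-out lower numbers stand for less inhibition and higher numbers for more inhibition at the one concentration tested (going by the name of the read-out)), compound 2 gives 30%, the higher of the two numbers, while compound 1 gives -8%, a gap beyond the scatter. Compound 3 `CO[C@@H]1O[C@H](COc2ccccc2)[C@@H](O)[C@H](O)[C@H]1Oc1ccc(OC2CCCCC2)cc1` has not been measured; it differs from compound 2 by hydrogen in place of phenyl on an aromatic carbon. Among the compounds with values here, no measured pair shows this change, so the expected size is uncertain, but compound 1, whose reading in this assay is -8%, suggests a move downward. The estimate for compound 3 in this assay is 5%, between -15% and 25%, a step of a number 25 percentage points lower from compound 2 to compound 3 (beyond the scatter).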

Compound 3, a percentage reported as inhibition, at one concentration (the size of the read-out at that concentration, not a potency): 14%
For compound 3 the middle estimate is 9 percentage points below the measured one, within the range that was stated.
By their numbers in this assay, from the lowest: compound 1; then compound 3; then compound 2.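

In this assay, the change from 4-phenylphenyl to phenyl gives a number 16 percentage points lower from compound 2 to compound 3 (beyond the scatter), so the outer phenyl contributes to the reading at this position, though compound 3 keeps some inhibition. The configuration at one saturated ring carbon matters as well, with a number 22 percentage points higher from compound 1 to compound 3 (beyond the scatter). That step isolates the drawn configuration from any other change: the fact that compounds 1 and 3 differ only in the configuration as drawn.

From the compounds shown here alone, it remains open whether an amine or a carboxylic acid on this aromatic carbon would raise or lower the reading. Going by these compounds, the effect of the stereocentre with the 4-phenylphenyl group in place also remains open.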